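Swapping a sugar-bearing triazole for a basic amine chain

The source may report more compounds than this note shows. Statements on the series, on what has been measured and on what is new or still open speak of the compounds shown alone.

Of the compounds shown here, three sharing one core have been measured in a functional assay on A549 cells (Homo sapiens) for cytotoxicity, read by MTT assay, with a stated time of 72 h; a lower number here means a stronger inhibitor, a higher number a weaker inhibitor. Compound 1 `O=C1c2c[n+]([O-])c3ccccc3c2C(=O)c2c1c1ccccc1n2Cc1cn([C@H]2C[C@H](O)[C@@H](CO)O2)nn1` gives 350 nM. Compound 2 `O=C1c2c[n+]([O-])c3ccccc3c2C(=O)c2c1c1ccccc1n2Cc1cn(C[C@@H](O)CO)nn1` gives 390 nM, and compound 3 `O=C1c2c[n+]([O-])c3ccccc3c2C(=O)c2c1c1ccccc1n2Cc1cn([C@@H]2O[C@H](CO)[C@@H](O)[C@H](O)[C@H]2O)nn1` gives 560 nM. Compound 2 stands second highest of these three numbers, with compound 1 nearest and compound 3 furthest, and every gap among them is within the scatter: a 1.1-fold higher number from compound 1 to compound 2 (0.05 log units; within the scatter), a 1.6-fold higher number from compound 1 to compound 3 (0.20 log units; within the scatter) and a 1.4-fold higher number from compound 2 to compound 3 (0.16 log units; within the scatter). All three measured steps exchange only the group on the aromatic nitrogen of the triazole, and none of them moves the number beyond the scatter.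

Compound 4 `CN1CCN(CCCCn2c3c(c4ccccc42)C(=O)c2c[n+]([O-])c4ccccc4c2C3=O)CC1` is not yet measured. It differs from compound 2 in a larger way: 3-(4-methylpiperazin-1-yl)propyl in place of 1-(2,3-dihydroxypropyl)-1H-1,2,3-triazol-4-yl on a saturated chain carbon bound to an aromatic nitrogen. Here the whole 1-(2,3-dihydroxypropyl)-1H-1,2,3-triazol-4-yl group leaves and 3-(4-methylpiperazin-1-yl)propyl enters on a saturated chain carbon bound to an aromatic nitrogen. For the measured compounds named here, no measured step removes the triazole itself, so the three steps bear on this change only indirectly, by showing that the core tolerates varied groups at this end with little effect.

Compound 4 is therefore expected to give about 250 nM, with a plausible range from 50 nM to 1200 nM. The expected step of a 1.6-fold lower number from compound 2 to compound 4 (0.19 log units; within the scatter) is estimated to fall within the scatter, with wide uncertainty.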

Compound 4, half-maximal inhibitory concentration: 90 nM
Beside the measured number, compound 4's estimate is 2.8-fold (0.44 log units) above it; the measured number falls inside the stated range.
By their numbers in this assay, from the lowest: compound 4; then compounds 1, 2 and 3 (each within the scatter of the next).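

In this assay, for the compounds shown here, the exchange of the 1-(2,3-dihydroxypropyl)-1H-1,2,3-triazol-4-yl group for 3-(4-methylpiperazin-1-yl)propyl gives a 4.3-fold lower number from compound 2 to compound 4 (0.64 log units; beyond the scatter), the first step in this set to leave the scatter. Going by these compounds alone, the three triazole compounds showed only that different groups on the triazole nitrogen leave the number within the scatter, whereas this result shows that what sits on a saturated chain carbon bound to an aromatic nitrogen can move the number, here towards a stronger inhibitor. The step changes several things at once, since the aromatic triazole ring and both hydrogen-bond donors leave while a six-membered non-aromatic ring enters, and nothing shown explains the shift.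

The compounds shown cannot separate the loss of the triazole from the gain of the 4-methylpiperazine, and a triazole carrying that 4-methylpiperazine would begin to pull the two apart. A butyl chain ending in morpholine or in a dimethylamine, or a shorter chain ending in the same 4-methylpiperazine, would show how much of the step depends on the ring nitrogens and on the chain length.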